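The source may hold more compounds than are shown below. What is called first, only, known or untested is meant among the compounds shown, and "the series" means these compounds.

Two compounds of this series carry numbers in a functional assay on HT-29 cells (Homo sapiens) for cytotoxicity, read by MTT assay, with a stated time of 72 h; on this read-out lower numbers stand for stronger inhibition and higher numbers for weaker inhibition. Compound 1 `Cn1c(=O)c(C(=O)Nc2ccc(Oc3ccncc3-c3cccnc3)c(F)c2)nn(-c2c(Cl)cccc2Cl)c1=O` gives 780 nM in this assay. Compound 2 `O=C(Nc1ccc(Oc2ccncc2-c2cccnc2)c(F)c1)c1nn(-c2cccc(F)c2)c(=O)c2ccccc12` gives 410 nM in this assay, the smaller of the two numbers as read, with compound 1 the nearest; the gap between them lies within the scatter, so nothing separates the two on this read-out. Compound 3 `O=C(Nc1ccc(Oc2ccncc2-c2cccnc2)c(F)c1)c1nn(-c2ccc(Cl)cc2)c(=O)c2ccccc12` has not yet been measured in this assay. It differs from compound 2 in one place: 4-chlorophenyl in place of 3-fluorophenyl on an aromatic nitrogen. Within the data shown here, no pair of measured compounds differs by a change of this kind, so the numbers give no direction for it. The expected step is small, in no settled direction, and none beyond the scatter: the estimated step is a 1.0-fold higher number from compound 2 to compound 3 (0.01 log units; within the scatter). Compound 3 is expected to give about 420 nM in this assay, estimated to fall between 160 nM and 1100 nM.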

Compound 3, half-maximal inhibitory concentration: 710 nM
Estimate against measurement, compound 3: 1.7-fold (0.23 log units) below, and the stated range covers the measured number.
By their numbers in this assay, from the lowest: compounds 2, 3 and 1 (each within the scatter of the next).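

In this assay, among these compounds, the change from 3-fluorophenyl to 4-chlorophenyl on the aromatic nitrogen gives the first step that can be read at this position: a 1.7-fold higher number from compound 2 to compound 3 (0.24 log units; within the scatter) and so leaves the two compounds unseparated on this read-out. Within this pair, the position accepts a different halogen at a different place on the phenyl ring with no change beyond the scatter. No measurement at hand bears on the reason for this result.

This single step changes the halogen and its place together, so the contribution of each remains unresolved. Also open, going by these compounds, is whether the position stays as flat with an unsubstituted phenyl, or with a phenyl carrying a methoxy group, an amine or a carboxylic acid, and whether a step beyond the scatter can be found there.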